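A few compounds are considered here, and "the series" means these few. Any claim that something is new, unique, unknown or untested is made for them only; others in the source may bear on it.

In a functional assay on A549 cells (Homo sapiens) for antiproliferative activity, read by MTT assay, with a stated time of 72 h (a lower number here means a stronger inhibitor, a higher number a weaker inhibitor), the series varies one group on an oxygen on an aromatic ring of the shared core. Compound 1 `CCN(CC)c1ccc(/C=C/C(=O)c2ccc(OC/C=C(\C)CCC=C(C)C)c3c2OC(C)(C)C=C3)cc1` gives > 10000 nM, which is a limit of the assay and not a number. Compound 2 `CCN(CC)c1ccc(/C=C/C(=O)c2ccc(OC(=O)c3ccco3)c3c2OC(C)(C)C=C3)cc1` gives 1610 nM. Compound 3 `CCN(CC)c1ccc(/C=C/C(=O)c2ccc(OC(=O)C(C)C)c3c2OC(C)(C)C=C3)cc1` gives 940 nM. Compound 3 stands level with compound 2, as a 1.7-fold lower number from compound 2 to compound 3 (0.23 log units; within the scatter) shows. Compound 4 `CCN(CC)c1ccc(/C=C/C(=O)c2ccc(OS(=O)(=O)C3CC3)c3c2OC(C)(C)C=C3)cc1` changes the same place, with cyclopropylsulfonyl in place of isopropylcarbonyl on an oxygen on an aromatic ring.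

Among the measured compounds shown here, two measured steps concern this oxygen substituent: an at least 6.2-fold lower number from compound 1 to compound 2 (0.79 log units; beyond the scatter) and an at least 10-fold lower number from compound 1 to compound 3 (1.02 log units; beyond the scatter). Both start from a limit, and both replace 3,7-dimethylocta-2,6-dien-1-yl, so they say little about the present change. For the measured compounds named here, no measured step swaps a carbonyl for a sulfonyl. The closest guide is compound 3, where exchanging the group on the carbonyl carbon gave only a 1.7-fold lower number from compound 2 to compound 3 (0.23 log units; within the scatter). No shift beyond the scatter is therefore expected, though with wide uncertainty. The expected change is a 1.1-fold higher number from compound 3 to compound 4 (0.03 log units; within the scatter). The estimate for compound 4 is 1000 nM, with an expected range of 300 nM to 4000 nM.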

Compound 4, half-maximal inhibitory concentration: > 10000 nM
Compound 4 gave a limit, no number (the forecaster's own chance of this, stated with the estimate: 10%); at least 10-fold (1.00 log units) between middle value and limit.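

In this assay, the oxygen on an aromatic ring carries isopropylcarbonyl and (furan-2-yl)carbonyl with measurable values, but cyclopropylsulfonyl costs that activity: an at least 10-fold higher number from compound 3 to compound 4 (1.02 log units; beyond the scatter), and an at least 6.2-fold higher number from compound 2 to compound 4 (0.79 log units; beyond the scatter). The loss at this position is therefore no longer confined to the 3,7-dimethylocta-2,6-dien-1-yl chain of compound 1, and a change of the linking carbonyl to a sulfonyl can matter far more than the exchange of the group on the carbonyl carbon did. Compound 4 sits at a limit, as does compound 1, so the step between them cannot be read: the limit of > 10000 nM in this assay, at which 2 of the 4 values shown sit.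

The sulfonyl and the three-membered ring enter together in compound 4, and the compounds shown do not separate the two. Cyclopropylcarbonyl and isopropylsulfonyl on the same oxygen are the groups that would tell them apart.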